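Trimming the acyl chain: from chloropentanoyl to methoxyacetyl

A few compounds are considered here, and "the series" means these few. Any claim that something is new, unique, unknown or untested is made for them only; others in the source may bear on it.

In a functional assay on KYSE-450 cells (Homo sapiens) for inhibition, read by MTT assay, with a stated time of 48 h (on this read-out higher numbers stand for weaker inhibition and lower numbers for stronger inhibition), compound 1 `COc1ccc(CN(C(C)=O)c2cc(OC)c(OC)c(OC)c2)cc1O` gives 160 nM. Compound 2 `COc1ccc(CN(C(=O)CCCCCl)c2cc(OC)c(OC)c(OC)c2)cc1O` gives 770 nM in this assay, the higher of the two numbers; the step of a 4.8-fold higher number from compound 1 to compound 2 (0.68 log units; beyond the scatter) marks it. Compound 3 `COCC(=O)N(Cc1ccc(OC)c(O)c1)c1cc(OC)c(OC)c(OC)c1` is not yet measured, and the change methoxy in place of 3-chloropropyl on a saturated chain carbon bound to a carbonyl carbon removes the group whose arrival raised the number. Among the measured compounds shown here, only that one step bears on the case, and it runs the other way. For the measured compounds named here, compound 3 is therefore expected to move back toward compound 1, by a 2.6-fold lower number from compound 2 to compound 3 (0.41 log units; beyond the scatter), though the methoxy has no precedent here. The estimate for compound 3 is 300 nM, within 120 nM to 750 nM.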

Compound 3, half-maximal inhibitory concentration: 460 nM
The estimate for compound 3 lay 1.5-fold (0.19 log units) below the measured number; the range from low to high includes it.
By their numbers in this assay, from the lowest: compound 1; then compounds 3 and 2 (each within the scatter of the next).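

Exchanging 3-chloropropyl for methoxy on a saturated chain carbon bound to a carbonyl carbon gives a 1.7-fold lower number from compound 2 to compound 3 (0.22 log units; within the scatter), so this assay does not separate these two groups. Methoxy in place of hydrogen at the same place still gives a 2.9-fold higher number from compound 1 to compound 3 (0.46 log units; beyond the scatter), so among these compounds both substituents stand apart from hydrogen, with or without chlorine. Nothing measured here accounts for this result. From the compounds shown here alone, what remains open is whether a small ethyl group, an amine or a carboxylic acid at this place would stay with compound 2 and compound 3 or return toward compound 1.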